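The source may hold more compounds than are shown below. What is called first, only, known or untested is meant among the compounds shown, and "the series" means these compounds.

Two members of the series have been measured in a functional assay on OVCAR-4 cells (Homo sapiens) for inhibition, read by sulforhodamine B assay, with a stated time of 48 h, tested at 10 uM; a higher number here means more inhibition of growth at the concentration tested, a lower number less inhibition of growth. Compound 1 `CCOC(=O)c1ccc(Nc2ccnc(SCC(=O)c3ccc([N+](=O)[O-])cc3)n2)cc1` gives 20% in this assay. Compound 2 `CC(=O)c1cccc(Nc2ccnc(SCC(=O)c3ccc(-c4ccccc4)cc3)n2)c1` gives 12% in this assay; the two numbers sit within the usual scatter of each other, so compound 2 is not set apart from compound 1. Compound 3 `COc1ccc(C(=O)CSc2nccc(Nc3cccc(C(C)=O)c3)n2)cc1` is not yet measured. It differs from compound 2 by methoxy in place of phenyl on an aromatic carbon. For the measured compounds named here, no measured pair shows this change, so no step beyond the scatter is expected in this assay, in either direction. Compound 3 is estimated at 14%, with a range from 0% to 32%. The expected step is a number 2 percentage points higher from compound 2 to compound 3 (within the scatter).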

Compound 3, percent growth inhibition at one concentration: 19%
Compound 3: the middle estimate sits 5 percentage points below what was measured; low and high end bracket the measured number.
By their numbers in this assay, from the lowest: compounds 2, 3 and 1 (each within the scatter of the next).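

At this position, para to a large group, methoxy in place of phenyl gives a number 7 percentage points higher from compound 2 to compound 3 (within the scatter) in this assay. For the compounds shown here, the phenyl ring can therefore give way to a much smaller group with an oxygen without a step beyond the scatter, which the earlier compounds could not show. Nothing at hand offers a reason for this result. Still open, on these data alone, is whether an amine or a carboxylic acid at this position would give a step beyond the scatter. As far as these compounds go, a longer chain, such as butoxy in place of methoxy, remains equally open.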